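The compounds below may be only part of what the source reports. "The series", "measured", "known", "first", "only" and "open" are said of these compounds alone.

Compound 1, with the structure `Nc1nc(Cl)c2ncn(Cc3ccccc3CCl)c2n1`, is the compound with the lowest number of the two plain values shown: in a functional assay on OVCAR-4 cells (Homo sapiens) for cytotoxicity, read by sulforhodamine B assay, with a stated time of 48 h (a lower number here means that less compound is tolerated, a higher number that more compound is tolerated), compound 1 gives 50100 nM, and compound 3, with the structure `ClCc1ccccc1Cn1cnc2ncnc(Cl)c21`, gives 77600 nM, a gap within the scatter. Compound 2, with the structure `ClCc1ccccc1Cn1cnc2nc(Cl)nc(Cl)c21`, reaches only a limit of this assay, > 100000 nM. Among the compounds with values here, the one measured step, an at least 1.2-fold lower number from compound 2 to compound 3 (0.11 log units; that floor lies within the scatter), removes a substituent and stays within the scatter, and the limit of > 100000 nM in this assay, at which 1 of the 3 values shown sits, caps what that step can show. Compound 4, with the structure `ClCc1ccccc1Cn1cnc2c(Cl)ncnc21`, differs from compound 1 by hydrogen in place of amino on an aromatic carbon. On that evidence no step beyond the scatter is expected, so compound 4 is estimated at 70000 nM, between 35000 nM and 140000 nM, an expected step of a 1.4-fold higher number from compound 1 to compound 4 (0.15 log units; within the scatter).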

Compound 4, concentration lethal to 50% of the cells: 45700 nM
The estimate for compound 4 lay 1.5-fold (0.19 log units) above the measured number; the range from low to high includes it.
By their numbers in this assay, from the lowest: compounds 4, 1 and 3 (each within the scatter of the next). At a limit, above all of these: compound 2.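

Replacing amino with hydrogen on the aromatic carbon between two ring nitrogen atoms gives a 1.1-fold lower number from compound 1 to compound 4 (0.04 log units; within the scatter), so in this assay the amino group can go with no change beyond the scatter. Unlike the earlier step, this one joins two plain numbers and can be read in full. Compound 2 alone stands at a limit, not a number: the limit of > 100000 nM in this assay, at which 1 of the 4 values shown sits.

On these data alone, whether a larger group on this carbon, such as a dimethylamino or methoxy group, would move the number stays open. So does the effect of a carboxylic acid there.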